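Morpholine Amide Replaces Cyclopentylamine in a Dimethoxy Series

The compounds below may be only part of what the source reports. "The series", "measured", "known", "first", "only" and "open" are said of these compounds alone.

Measured compounds:
compound 1, `CNC(=O)CC1CCc2cc(OC)c(OC)cc21`, 29%
compound 2, `COc1cc2c(cc1OC)C(CC(=O)NC1CCCC1)CC2`, 43.5%

In a functional assay on the whole organism (strain Wistar) for inhibition, with Rattus norvegicus as the target, read by paw edema, with stated times of 60 min and 3 h, at a dose of 100 mg/kg by the oral route (a higher number here means more inhibition at the dose given (going by the name of the read-out), a lower number less inhibition), compound 2 stands highest of the two numbers recorded; its nearest neighbour is compound 1, and the step of a number 14.5 percentage points higher from compound 1 to compound 2 (beyond the scatter) came with cyclopentyl in place of methyl on an amide-type nitrogen. Compound 3, `COc1cc2c(cc1OC)C(CC(=O)N1CCOCC1)CC2`, has not been measured. It differs from compound 2 by morpholin-4-yl in place of cyclopentylamino on a carbonyl carbon. Within the data shown here, no measured step touches this kind of change: the one known step altered the substituent on the amide nitrogen while keeping the amide hydrogen, whereas here the amide hydrogen is lost and the ring enters on the nitrogen itself. Among the measured compounds shown here, the only guide is the moderate size of the one step from compound 1 to compound 2 in this assay. Compound 3 is therefore expected to lie near compound 2, with a step of a number 7.5 percentage points lower from compound 2 to compound 3 (within the scatter), and the estimate for compound 3 is 36%, in the range 16% to 56%.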

Compound 3, a percentage reported as inhibition, in the whole organism at one dose (the size of the read-out at that dose, not a potency): 19.6%
Compound 3: middle estimate off by 16.4 percentage points, on the high side; low and high end bracket the measured number.
By their numbers in this assay, from the lowest: compounds 3 and 1 (each within the scatter of the next); then compound 2.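

In this assay, the step of a number 23.9 percentage points lower from compound 2 to compound 3 (beyond the scatter) shows that the gain at this position does not carry over to every ring on the carbonyl carbon, even though cyclopentylamino and morpholin-4-yl both have 6 heavy atoms. The step of a number 9.4 percentage points lower from compound 1 to compound 3 (within the scatter) adds that morpholin-4-yl cannot be told apart from the much smaller methylamino, so of the three groups only cyclopentylamino stands out. Nothing available here explains this loss.

From the compounds shown here alone, what remains open is which part of the change matters, as morpholin-4-yl both removes the amide hydrogen and brings a ring oxygen. Piperidin-1-yl, with no amide hydrogen and a ring of carbon apart from its nitrogen, and tetrahydropyran-4-ylamino, with the amide hydrogen and a ring oxygen, would separate the two.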